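The source may report more compounds than this note shows. Statements on the series, on what has been measured and on what is new or still open speak of the compounds shown alone.

In an ADME assay on RAW264.7 cells (Mus musculus) for cytotoxicity, read by neutral red uptake, with a stated time of 24 h (a higher number here means that more compound is tolerated, a lower number that less compound is tolerated), compound 1 `O=C(CN1C(=O)S/C(=C\c2ccc(C(F)(F)F)cc2)C1=O)NOCc1ccccc1` gives no number, only a limit of > 128000 nM. Compound 2 `C=CCONC(=O)CN1C(=O)S/C(=C\c2ccc(C(F)(F)F)cc2)C1=O` also gives only a limit, > 128000 nM. Compound 3 `CC(C(=O)NOCc1ccccc1)N1C(=O)S/C(=C\c2ccc(C(F)(F)F)cc2)C1=O` again gives only a limit, > 128000 nM. What these compounds share on the numbers is the limit of > 128000 nM in this assay, at which 3 of the 3 values shown sit.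

Compound 4 `CCCC/C=C1\SC(=O)N(CC(=O)NOCc2ccccc2)C1=O` keeps the core of compound 1 but differs by butyl in place of 4-(trifluoromethyl)phenyl on a double-bonded chain carbon bound to a double-bonded ring carbon: butyl in place of 4-(trifluoromethyl)phenyl, on a double-bonded chain carbon bound to a double-bonded ring carbon. Two measured changes start from compound 1, and neither reaches this place. For the measured compounds named here, the first is a step that the two limits leave unreadable from compound 1 to compound 2, and the second is a step that the two limits leave unreadable from compound 1 to compound 3. Neither size can be read, so they give no direct guide to this swap, and no direction can be foreseen. With all the readings sitting at one limit, the estimated change is a number no higher from compound 1 to compound 4 (the limit leaves the size open), and nothing beyond the scatter is expected. For compound 4 the expected value is 128000 nM, with an estimated range from 50000 nM to 256000 nM.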

Compound 4, half-maximal cytotoxic concentration: > 128000 nM
Compound 4: a limit, no number (the forecaster's own chance of this, stated with the estimate: 70%); the middle value sits exactly at the limit.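

In this assay compound 4 gives only the limit > 128000 nM and no number, so the step from compound 1 to compound 4 cannot be read. The compounds shown leave open what concentration any of them takes to reach the half-maximal cytotoxic read-out, and whether butyl and 4-(trifluoromethyl)phenyl differ at all.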